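Swapping chloro for hydrogen on compound 2

The compounds below may be only part of what the source reports. "The series", "measured", "known", "first", "only" and "open" are said of these compounds alone.

Compound 1 `CCCCc1ccc(Nc2nc3c(ncn3[C@@H]3C[C@@H](O)[C@H](CO)O3)c(=O)[nH]2)cc1`: 25000 nM
Compound 2 `CCCCc1ccc(Nc2nc(Cl)c3ncn([C@@H]4C[C@@H](O)[C@H](CO)O4)c3n2)cc1`: 10300 nM

In a functional assay on HeLa cells (Homo sapiens) for inhibition (a lower number here means a stronger inhibitor, a higher number a weaker inhibitor), compound 2 has the lower of the two numbers, and its gap to compound 1 lies beyond the usual scatter. Compound 3 `CCCCc1ccc(Nc2ncc3ncn([C@@H]4C[C@@H](O)[C@H](CO)O4)c3n2)cc1` differs from compound 2 in one place: hydrogen in place of chloro on an aromatic carbon. For the measured compounds named here, no measured pair shows this change, so any expectation is uncertain. A modest rise in the number is expected in this assay, staying near the span from compound 2 at 10300 nM to compound 1 at 25000 nM. The expected step is a 1.7-fold higher number from compound 2 to compound 3 (0.24 log units; within the scatter). The estimated value for compound 3 is 18000 nM, with an expected range of 7000 nM to 45000 nM.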

Compound 3, half-maximal inhibitory concentration: 5000 nM
Compound 3: middle estimate off by 3.6-fold (0.56 log units), on the high side; measured number below the stated range.
By their numbers in this assay, from the lowest: compound 3; then compound 2; then compound 1.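

For the compounds shown here, with a 2.1-fold lower number from compound 2 to compound 3 (0.31 log units; beyond the scatter) in this assay, this is the first direct reading of this position: on the aromatic carbon next to the ring nitrogen, the chloro group is not needed for inhibition. Of the two, plain hydrogen gives the lower number, so the smaller substituent is the better one here. Nothing available explains this step. On these data alone, it remains open whether hydrogen is the best choice at this carbon, or whether a fluoro, a methyl or an amine there would lower the number further.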